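The source may hold more compounds than are shown below. What is called first, only, known or untested is meant among the compounds shown, and "the series" means these compounds.

Measured compounds and their values:
- compound 1, `Brc1cn2ccnc2c(-c2ccc3ncn(C4CCCCC4)c3c2)n1`, gives 17.2%
- compound 2, `COc1ccc(-c2cn3ccnc3c(-c3ccc4ncn(C5CCCCC5)c4c3)n2)cc1`, gives 95.2%
- compound 3, `c1ccc2c(-c3cn4ccnc4c(-c4ccc5ncn(C6CCCCC6)c5c4)n3)cccc2c1`, gives 36.5%

All three share one core and differ only in the group attached at a single aromatic carbon. In a functional assay on PC-3 cells (Homo sapiens) for inhibition, read by sulforhodamine B assay, with a stated time of 48 h, tested at 10 uM (a higher number here means more inhibition at the concentration tested (going by the name of the read-out), a lower number less inhibition), compound 3 stands second highest of the three numbers. The step of a number 19.3 percentage points higher from compound 1 to compound 3 (beyond the scatter) was modest, whereas the step of a number 58.7 percentage points lower from compound 2 to compound 3 (beyond the scatter) was large, so compound 3 sits much nearer compound 1 than compound 2. The widest step in the set, a number 78 percentage points higher from compound 1 to compound 2 (beyond the scatter), shows how strongly this one position can shift the read-out.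

Compound 4, `c1cn2cc(-c3ccsc3)nc(-c3ccc4ncn(C5CCCCC5)c4c3)c2n1`, has not yet been measured in this assay. It differs from compound 3 in one place: thiophen-3-yl in place of naphthalen-1-yl on an aromatic carbon. The measured steps bearing on this change are the two that replace one group with another at the same carbon, and both were beyond the scatter, one modest and one large, in opposite directions. Thiophen-3-yl is a third kind of aromatic group, smaller than naphthalen-1-yl and bearing one sulfur, and nothing measured so far pins down which direction it will take. An increase is tentatively expected, of size a number 18.5 percentage points higher from compound 3 to compound 4 (beyond the scatter), with wide uncertainty. For compound 4 the estimate in this assay is 55%, with a range from 20% to 90%.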

Compound 4, a percentage reported as inhibition, at one concentration (the size of the read-out at that concentration, not a potency): 19.9%
Estimate against measurement, compound 4: 35.1 percentage points above, outside the stated range (below it).
By their numbers in this assay, from the lowest: compounds 1 and 4 (each within the scatter of the next); then compound 3; then compound 2.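

In this assay, the step of a number 75.3 percentage points lower from compound 2 to compound 4 (beyond the scatter) shows that an aromatic ring at this carbon does not by itself bring the high read-out of 4-methoxyphenyl, and the step of a number 16.6 percentage points lower from compound 3 to compound 4 (beyond the scatter) shows that thiophen-3-yl also falls short of naphthalen-1-yl. Going by these compounds alone, the step of a number 2.7 percentage points higher from compound 1 to compound 4 (within the scatter) adds something the earlier compounds could not show: thiophen-3-yl and bromo cannot be told apart here, so a ring in this place need not offer anything over a lone bromo group. Nothing available explains why these groups differ as they do.

The compounds shown leave open whether the high value of compound 2 belongs to its phenyl ring or to the methoxy group on that ring, a question that a plain phenyl group at this carbon would help to separate. They also leave open how a non-aromatic group, such as an amine or a morpholine, would behave in this position.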